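Swapping fluoro for methoxy on a urea series

The compounds below may be only part of what the source reports. "The series", "measured", "known", "first", "only" and "open" are said of these compounds alone.

Measured compounds:
Compound 1 `COc1cccc(-n2cc(COc3cccc(NC(=O)Nc4ccc(Cl)c(C(F)(F)F)c4)c3)nn2)c1`, 1310 nM
Compound 2 `O=C(Nc1cccc(OCc2cn(-c3ccccc3F)nn2)c1)Nc1ccc(Cl)c(C(F)(F)F)c1`, 1520 nM

Among the measured compounds shown here, in a functional assay on HepG2 cells (Homo sapiens) for inhibition, read by MTT assay, with a stated time of 72 h (a lower number here means a stronger inhibitor, a higher number a weaker inhibitor), compound 2 gives the highest of the two numbers, yet its gap to compound 1, the only neighbour, lies within the scatter. Compound 3 `COc1ccccc1-n1cc(COc2cccc(NC(=O)Nc3ccc(Cl)c(C(F)(F)F)c3)c2)nn1` differs from compound 2 by methoxy in place of fluoro on an aromatic carbon. For the measured compounds named here, the one measured step that bears on this, a 1.2-fold higher number from compound 1 to compound 2 (0.06 log units; within the scatter), also exchanged a methoxy-bearing ring for a fluoro-bearing one and stayed within the scatter. A step of similar size, not beyond the scatter, is therefore expected for a 1.1-fold lower number from compound 2 to compound 3 (0.04 log units; within the scatter). Compound 3 is estimated at 1400 nM, with a range from 700 nM to 2800 nM.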

Compound 3, half-maximal inhibitory concentration: 11300 nM
Estimate against measurement, compound 3: 8.1-fold (0.91 log units) below; the measured number lies above the stated range.
By their numbers in this assay, from the lowest: compounds 1 and 2 (each within the scatter of the next); then compound 3.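

Methoxy in place of fluoro on the aromatic carbon ortho to a large group is not a neutral swap: it gives a 7.4-fold higher number from compound 2 to compound 3 (0.87 log units; beyond the scatter), and 2-methoxyphenyl in place of 3-methoxyphenyl gives an 8.6-fold higher number from compound 1 to compound 3 (0.94 log units; beyond the scatter). Methoxy as such therefore does not go with the higher number, since compound 1 also carries it and lies within the scatter of compound 2; the place on the ring matters. Nothing available explains this rise. On these data alone, whether a hydroxyl or an ethoxy group at this place would track fluoro or methoxy remains open.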